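A few compounds are considered here, and "the series" means these few. Any claim that something is new, unique, unknown or untested is made for them only; others in the source may bear on it.

Compound 1: `CC(C)=CCC/C(C)=C/CC1Cc2c(O)cc(=O)n(CCCO)c2CC1(C)C` with 0% in a functional assay on PANC-1 cells (Homo sapiens) for inhibition, read by MTT assay, with a stated time of 24 h, tested at 10 uM; a lower number here means less inhibition, a higher number more inhibition at the concentration tested (going by the name of the read-out).
Compound 2: `COc1ccc(NC(=O)Oc2cc(=O)n(CCCO)c3c2CC(CC=C(C)C)C(C)(C)C3)cc1` with 0%.

Compound 1 gives 0% in this assay, and compound 2, which carries a carbamate built on the shared core, gives 0%. On these numbers compound 2 stands level with compound 1; the two values are within the usual scatter of each other, so nothing can be read into their difference.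

Compound 3 is `CC(C)=CCC1Cc2c(OC(=O)Nc3cccc(C(F)(F)F)c3)cc(=O)n(CCCO)c2CC1(C)C`. It differs from compound 2 in one place: 3-(trifluoromethyl)phenyl in place of 4-methoxyphenyl on an amide-type nitrogen. Among the compounds with values here, no measured pair of compounds shows what such a swap does in this assay, so there is no step to lean on. With compound 2 at 0% and compound 1 at the same reading, the only guidance is that this type of structure has so far shown no inhibition at the tested concentration.

The step expected from compound 2 to compound 3 is therefore a number 5 percentage points higher from compound 2 to compound 3 (within the scatter), which is no more than the scatter in either direction. Compound 3 is expected to give 5%, with a range from 0% to 25%.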

Compound 3, a percentage reported as inhibition, at one concentration (the size of the read-out at that concentration, not a potency): 0%
For compound 3 the middle estimate is 5 percentage points above the measured one; low and high end bracket the measured number.
By their numbers in this assay, from the lowest: compounds 1, 2 and 3 (each within the scatter of the next).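

Placing 3-(trifluoromethyl)phenyl in place of 4-methoxyphenyl on an amide-type nitrogen gives no change at the digits printed from compound 2 to compound 3 (within the scatter) in this assay and provides the first comparison here in which only one place differs. The two aryl groups differ in what they carry, yet neither gives a reading that sets it apart from the other at the single concentration tested. Within the data shown here, since both readings sit at nothing, the pair cannot show whether this position has any influence on the read-out, only that this swap does not bring out inhibition under these conditions. Nothing measured here offers an explanation for this result.

Still open, on these data alone, is whether any other group on this nitrogen would give a measurable reading, for example a phenyl ring carrying an amine or a carboxylic acid, or a longer alkyl chain in place of the ring. Also open, as far as these compounds go, is whether changing the 3-hydroxypropyl chain on the shared core would alter the picture.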